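Chloro in Place of Methoxy on a Shared Core

A few compounds are considered here, and "the series" means these few. Any claim that something is new, unique, unknown or untested is made for them only; others in the source may bear on it.

Three compounds were measured in a functional assay on SK-BR-3 cells (Homo sapiens) for inhibition, read by CCK-8 assay, with a stated time of 72 h, tested at 20 uM; on this read-out lower numbers stand for less inhibition of growth and higher numbers for more inhibition of growth at the one concentration tested:

compound 1 `COc1ccc2c(c1)/C(=C\C(=O)OC(C)(C)C)C(=O)N2` — 87.7%
compound 2 `COc1cccc2c1NC(=O)/C2=C/C(=O)OC(C)(C)C` — 87.7%
compound 3 `CC(C)(C)OC(=O)/C=C1/C(=O)Nc2ccc(Cl)cc21` — 87.6%

Compound 1 and compound 2 have the same atoms joined differently; the difference between the two cores is not broken down here. Their values in this assay are level at the digits given and lie within the scatter of each other, as does the value of compound 3, which is the furthest from compound 2 yet still within the scatter. Among the measured compounds shown here, the one counted change, (chloro in place of methoxy on an aromatic carbon), gave a number 0.1 percentage points lower from compound 1 to compound 3 (within the scatter).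

Compound 4 `CC(C)(C)OC(=O)/C=C1/C(=O)Nc2c(Cl)cccc21` is not yet measured. It arises from compound 2 by chloro in place of methoxy on an aromatic carbon. This is the same kind of change as from compound 1 to compound 3, though not the same: in compound 3 the chloro sits meta and para to a fused ring, in compound 4 ortho and meta to a fused ring. The expected step is a number 0.7 percentage points lower from compound 2 to compound 4 (within the scatter), resting on the flat step a number 0.1 percentage points lower from compound 1 to compound 3 (within the scatter) and on the level values of compound 1 and compound 2. Compound 4 is therefore estimated at 87%, between 76% and 95%.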

Compound 4, percent growth inhibition at one concentration: 88.2%
Compound 4: the middle estimate sits 1.2 percentage points below what was measured; the range from low to high includes it.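

In this assay, chloro in place of methoxy on an aromatic carbon gave a number 0.5 percentage points higher from compound 2 to compound 4 (within the scatter), and set beside the same change on the other core, the two steps agree: the same change on two cores in this assay, a number 0.1 percentage points lower (within the scatter) from compound 1 to compound 3 and a number 0.5 percentage points higher (within the scatter) from compound 2 to compound 4, 0.6 percentage points apart, within the scatter of two such steps Across these two pairs, then, the swap carries from one core to the other without a difference that can be told from the scatter, whether the chloro lands as in compound 3 or ortho to a fused ring and meta to a fused ring as in compound 4. This does not show that the change is neutral on other cores or at other concentrations, since the evidence is two pairs read at one concentration, and such a reading says nothing about how the compounds would compare across a range of doses.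

The compounds shown leave open what an amine or a nitrile on the same aromatic carbon would do to the growth inhibition. They also leave open whether a carboxylic acid in place of the tert-butyl ester would keep these values.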